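Cyclohexyl for methoxyphenyl on a weakly active core

The source may hold more compounds than are shown below. What is called first, only, known or untested is meant among the compounds shown, and "the series" means these compounds.

Among the measured compounds shown here, compound 1 `COc1ccc(N2C(=O)COc3ccc(-c4cnc5ccccc5c4)cc32)cc1` is one of three compounds measured in a functional assay on A-375 cells (Homo sapiens) for antiproliferative activity, read by MTT assay, with a stated time of 72 h; a lower number here means a stronger inhibitor, a higher number a weaker inhibitor. In this assay compound 1 reaches only the limit of the assay, > 40000 nM, and not a number. Compound 3 `O=C1COc2ccc(-c3ccc(O)cc3)cc2N1` likewise sits at the limit in this assay, giving > 40000 nM. Compound 2 `O=C1COc2ccc(-c3cnc(Cl)c(NS(=O)(=O)c4ccc(F)cc4)c3)cc2N1c1ccccc1` gives 36900 nM in this assay. Most of what is known here is therefore (the limit of > 40000 nM in this assay, at which 2 of the 3 values shown sit). Compound 4 `O=C1COc2ccc(-c3cnc4ccccc4c3)cc2N1C1CCCCC1` has not yet been measured; it differs from compound 1 by cyclohexyl in place of 4-methoxyphenyl on an amide-type nitrogen in a ring. No step between measured compounds is known, so nothing shown separates the effect of one change from another. Compound 4 is expected to remain weak, with an estimate of 30000 nM in this assay, between 8000 nM and 80000 nM. The step that this estimate means, an at least 1.3-fold lower number from compound 1 to compound 4 (0.12 log units; that floor lies within the scatter), is expected to stay within the usual scatter.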

Compound 4, half-maximal inhibitory concentration: > 40000 nM
Compound 4: no number, only a limit (the forecaster's own chance of this, stated with the estimate: 55%); middle value at least 1.3-fold (0.12 log units) away from the limit.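

Among the compounds shown here, compound 1 and compound 4 both give only a limit in this assay, and no step between them can be read. The compounds shown leave open whether cyclohexyl in place of 4-methoxyphenyl on this nitrogen changes activity at all.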